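The source may report more compounds than this note shows. Statements on the series, on what has been measured and on what is new or still open speak of the compounds shown alone.

For the measured compounds named here, compound 2 `C#CCN(C)CCCOc1ccc2ccc(=O)oc2c1` is one of two compounds measured in an ADME assay on isolated protein for inhibition of Amine oxidase [flavin-containing] A (Homo sapiens), read by fluorescence and Amplex Red, with stated times of 15 min and 20 min; on this read-out lower numbers stand for stronger inhibition and higher numbers for weaker inhibition. In this assay compound 2 gives 36900 nM, the lower of the two numbers; compound 1 `C#CCN(CCCOc1ccc2ccc(=O)oc2c1)Cc1ccc(C)cc1` gives 116000 nM. Going by the values given here, the only measured step joins these two: a 3.1-fold lower number from compound 1 to compound 2 (0.50 log units; beyond the scatter), and the change it describes is hydrogen in place of 4-methylphenyl on a saturated chain carbon bound to an amine nitrogen.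

Compound 3 `C#CCN(CCCOc1ccc2ccc(=O)oc2c1)Cc1ccccc1` has not been measured. Compared with compound 2 it carries phenyl in place of hydrogen on a saturated chain carbon bound to an amine nitrogen. This runs the measured step backwards in kind, only without the methyl on the entering ring, so the step from compound 1 to compound 2 is the one that bears on it, and its size, beyond the scatter, suggests a move back towards a higher number. For compound 3 the expected step is a 2.4-fold higher number from compound 2 to compound 3 (0.39 log units; beyond the scatter). The estimate for compound 3 in this assay is 90000 nM, with a range from 40000 nM to 200000 nM.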

Compound 3, half-maximal inhibitory concentration: 38600 nM
Compound 3: middle estimate off by 2.3-fold (0.37 log units), on the high side; the measured number lies below the stated range.
By their numbers in this assay, from the lowest: compounds 2 and 3 (each within the scatter of the next); then compound 1.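

In this assay, the change from methyl to benzyl on the amine nitrogen leaves the two numbers within the scatter of each other (a 1.0-fold higher number from compound 2 to compound 3 (0.02 log units; within the scatter)). Among these three compounds, then, adding the unsubstituted phenyl alone does not separate the numbers, whereas the methyl on the aromatic carbon does: with hydrogen in its place, the reading is (a 3.0-fold lower number from compound 1 to compound 3 (0.48 log units; beyond the scatter)). Nothing available here explains why this small methyl changes the number when the larger phenyl does not.

From the compounds shown here alone, it remains open whether other groups on that aromatic carbon, such as chlorine or methoxy, would also give a higher number than hydrogen does. Also open, going by these compounds, is whether a longer chain carrying the phenyl, as in phenethyl, would read like benzyl or differently.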